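The source may hold more compounds than are shown below. What is called first, only, known or untested is meant among the compounds shown, and "the series" means these compounds.

Three thiourea compounds, compound 1 `O=C(NC(=S)N1CCc2c(OCc3ccccc3)cccc21)c1ccccc1`, compound 2 `O=C(NC(=S)N1CCc2cccc(OCc3ccccc3)c21)c1ccccc1` and compound 3 `Cc1ccc(C(=O)NC(=S)N2CCc3c(OCCCCCOc4ccc(Cl)cc4)cccc32)cc1`, were examined in an ADME assay on Huh-7 cells (Homo sapiens) for cytotoxicity; a higher number here means that more compound is tolerated, a lower number that less compound is tolerated. In this assay compound 1 gives > 50000 nM, a limit of the assay and not a number. Compound 2 likewise gives > 50000 nM, which is also a limit. Compound 3 gives > 50000 nM, again a limit rather than a measured value. Compound 3 thus stands at the limit of > 50000 nM in this assay, at which 3 of the 3 values shown sit. Compound 4 `O=C(NC(=S)N1CCc2c(OCCCCCOc3ccc(Cl)cc3)cccc21)c1ccno1` differs from compound 3 in one place: 1,2-oxazol-5-yl in place of 4-methylphenyl on a carbonyl carbon. Going by the values given here, no pair of measured compounds differs in a single place, so no measured step is known for this change. The expected step from compound 3 to compound 4 in this assay is a step that the limit leaves unreadable from compound 3 to compound 4, none beyond the scatter. Compound 4 is therefore estimated at 60000 nM, within 30000 nM to 120000 nM.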

Compound 4, half-maximal cytotoxic concentration: 37100 nM
Beside the measured number, compound 4's estimate is 1.6-fold (0.21 log units) above it; low and high end bracket the measured number.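

With 1,2-oxazol-5-yl in place of 4-methylphenyl on a carbonyl carbon, this assay shows an at least 1.3-fold lower number from compound 3 to compound 4 (0.12 log units; that floor lies within the scatter). Compound 4 is the first compound here to give a number rather than a limit, but this change is not shown to lower tolerance beyond the scatter. The true size of the step cannot be read because the value for compound 3 is only a limit: the limit of > 50000 nM in this assay, at which 3 of the 4 values shown sit.

The compounds shown leave open how an amine, a carboxylic acid or a pyridine ring on this carbonyl carbon would read in this assay.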